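The source may report more compounds than this note shows. Statements on the series, on what has been measured and on what is new or still open speak of the compounds shown alone.

Measured compounds in a physicochemical assay for lipophilicity; on this read-out higher numbers stand for higher lipophilicity and lower numbers for lower lipophilicity:
Compound 1, `COc1c(OC)c(OC(=O)C(C)(C)C)c2c(OC)cccc2c1OC(=O)C(C)(C)C`, gives 5.6.
Compound 2, `COc1ccc2c(OC(=O)C(C)(C)C)c(OC)c(OC)c(OC(=O)C(C)(C)C)c2c1`, gives 5.4.
Compound 3, `COc1c(OC)c(OC(=O)C(C)(C)C)c2c(C)cccc2c1OC(=O)C(C)(C)C`, gives 6.1.

Compound 1 and compound 2 are built from the same atoms joined differently; the difference between the two cores is not broken down here. Compound 2 has the lowest of the three numbers, but compound 1 lies within the scatter of it, while compound 3 lies beyond the scatter above both. Compound 1 and compound 3 differ by methyl in place of methoxy on an aromatic carbon, and in this assay this gave a number 0.50 log units higher from compound 1 to compound 3 (beyond the scatter).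

Compound 4, `COc1c(OC)c(OC(=O)C(C)(C)C)c2cc(C)ccc2c1OC(=O)C(C)(C)C`, has not yet been measured. It differs from compound 2 by methyl in place of methoxy on an aromatic carbon. This is the same kind of change as from compound 1 to compound 3, though the place differs: there the carbon is ortho to a fused ring and meta to a fused ring, here it is meta to a fused ring and para to a fused ring. A step in this assay of about a number 0.50 log units higher from compound 2 to compound 4 (beyond the scatter) is expected for compound 4. That rests on the value of compound 2, 5.4, and on the step of a number 0.50 log units higher from compound 1 to compound 3 (beyond the scatter). Compound 4 is therefore estimated at 5.9, expected between 5.5 and 6.3.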

Compound 4, partition coefficient: 6.1
For compound 4 the middle estimate is 0.20 log units below the measured one, within the range that was stated.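

In this assay, methyl in place of methoxy on an aromatic carbon gave a number 0.70 log units higher from compound 2 to compound 4 (beyond the scatter), and the same change on the other core gave a number 0.50 log units higher from compound 1 to compound 3 (beyond the scatter), so on both cores the change went the same way and beyond the scatter. This shows that the direction of the step carried from one core to the other in these two pairs, even with the methyl at a different place on each, but two pairs give no rule for further cores or places and do not separate the part played by the core from that of the place. No evidence at hand bears on what lies behind either step.

The compounds shown leave open how an amine or a carboxylic acid in place of the methoxy would read in this assay. They also leave open whether a longer chain such as ethyl would follow methyl, and whether methyl on the remaining aromatic carbons would give a similar step.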